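Series notes: substituent change on the amide-type nitrogen

The compounds below may be only part of what the source reports. "The series", "measured", "known", "first", "only" and "open" are said of these compounds alone.

Measured so far:
compound 1 `CN(C(=S)SCc1ccc(C(=O)Nc2ccccc2N)cc1)c1cccnc1`: 82.5%
compound 2 `Cc1ccc(N2CCN(C(=S)SCc3ccc(C(=O)Nc4ccccc4N)cc3)CC2)cc1`: 19.8%

In a functional assay on MGC-803 cells (Homo sapiens) for antiproliferative activity, read by CCK-8 assay, with a stated time of 72 h, tested at 8 uM (on this read-out lower numbers stand for a weaker effect and higher numbers for a stronger effect at the one concentration tested), compound 1 gives 82.5% and stands highest of the two numbers; compound 2 gives 19.8%, a gap beyond the scatter. Compound 3 `CN(Cc1ccncc1)C(=S)SCc1ccc(C(=O)Nc2ccccc2N)cc1` is not yet measured. It differs from compound 1 by (pyridin-4-yl)methyl in place of pyridin-3-yl on an amide-type nitrogen. Among the measured compounds shown here, no measured pair shows this change, so its size is open; with the methyl kept and a single added carbon, a moderate decrease is expected, a number 20.5 percentage points lower from compound 1 to compound 3 (beyond the scatter), but a small or no change beyond the scatter is also possible. Compound 3 is expected to give 62%, within 28% to 85%.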

Compound 3, a percentage reported as inhibition, at one concentration (the size of the read-out at that concentration, not a potency): 83.2%
Estimate against measurement, compound 3: 21.2 percentage points below; measured number inside the range.
By their numbers in this assay, from the lowest: compound 2; then compounds 1 and 3 (each within the scatter of the next).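

On the amide-type nitrogen, (pyridin-4-yl)methyl in place of pyridin-3-yl is tolerated in this assay, with a number 0.7 percentage points higher from compound 1 to compound 3 (within the scatter). This position therefore accepts the added methylene carbon together with the changed pyridine attachment, although the step cannot separate these two changes. No measured property is at hand to account for this result. Still open, going by these compounds, is what (pyridin-3-yl)methyl would give on this nitrogen, which would separate the two changes. Also open, on these data alone, are a benzyl group, with no ring nitrogen, and a longer chain such as 2-(pyridin-4-yl)ethyl.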